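The source may hold more compounds than are shown below. What is called first, only, known or untested is meant among the compounds shown, and "the series" means these compounds.

In an ADME assay on a cell-free system (plasma, Mus musculus) for metabolic stability, read by HPLC, with a stated time of 120 min, tested at 2 uM (on this read-out lower numbers stand for a shorter-lived compound and higher numbers for a longer-lived compound), two compounds have been run so far. Compound 1, `CCCCCCNC(=O)N1C(=O)c2ccccc2C1=O`, gives 0.483 h. Compound 2, `COc1nc2ccccc2n1C(=O)NCCCCc1ccccc1`, reaches a limit of this assay rather than a number, reported as > 2 h. That limit is the one described by the limit of > 2 h in this assay, at which 1 of the 2 values shown sits. Going by the values given here, compound 2 therefore stands at the longer-lived end of the two values shown, and compound 1 is the only compound that carries an actual number.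

Compound 3, `O=C(NCCCCc1ccccc1)n1cnc2ccccc21`, has not yet been measured. It differs from compound 2 in one place: hydrogen in place of methoxy on an aromatic carbon. Among the compounds with values here, no pair of measured compounds differs in a single place, so no measured step shows what such a change does in this assay. The estimate here means a step of an at least 1.4-fold lower number from compound 2 to compound 3 (0.15 log units; that floor lies within the scatter), expected to run toward a shorter-lived compound and somewhat beyond the usual scatter, though the chance remains that the assay again reports only a limit. Compound 3 is expected to give about 1.4 h in this assay, with a range estimated from 0.5 h to 4 h.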

Compound 3, half-life in the plasma assay: > 2 h
Compound 3: only a limit was reported; the forecaster's own chance of this, stated with the estimate: 35%; middle value at least 1.4-fold (0.15 log units) from the limit.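

Going by these compounds alone, in the plasma assay compound 2 and compound 3 both stand at a limit of the assay, so no step between them can be read there. In a physicochemical assay for metabolic stability, read by HPLC, in phosphate buffer, at pH 7.4, tested at 10 uM (a higher number here means that the compound lasts longer, a lower number that the compound disappears faster), compound 2 also reaches a limit, > 2 h. In the physicochemical assay compound 3 gives 0.833 h. In the physicochemical assay this amounts to an at least 2.4-fold lower number from compound 2 to compound 3 (0.38 log units; beyond the scatter). The compounds shown leave open what hydrogen in place of methoxy on an aromatic carbon does in the plasma assay.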